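The source may hold more compounds than are shown below. What is called first, only, known or untested is meant among the compounds shown, and "the series" means these compounds.

Series notes on the shared core. Compound 1 `CCC(C)COc1cccc2ccc(N)nc12` gives 36 nM in an assay on cells with melanin-concentrating hormone receptor 1 (Homo sapiens) as the target, read by radioligand binding; on this read-out lower numbers stand for stronger inhibition and higher numbers for weaker inhibition. Compound 2 `CCOCC(C)Oc1cccc2ccc(N)nc12` gives 1070 nM, the step being a 30-fold higher number from compound 1 to compound 2 (1.47 log units; beyond the scatter). Compound 3 `Nc1ccc2cccc(OCC3CCCC3)c2n1` gives 53 nM; it stands second highest of the three numbers, with a 1.5-fold higher number from compound 1 to compound 3 (0.17 log units; within the scatter) on one side and a 20-fold lower number from compound 2 to compound 3 (1.31 log units; beyond the scatter) on the other.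

Compound 4 `CCCOc1cccc2ccc(N)nc12` is not yet measured. Its change from compound 3 is ethyl in place of cyclopentyl on a saturated chain carbon bound to an oxygen on an aromatic ring. The step that bears most directly on it is a 1.5-fold higher number from compound 1 to compound 3 (0.17 log units; within the scatter), which shows that exchanging one group without oxygen for another at this place leaves the number about where it was. The large steps of a 30-fold higher number from compound 1 to compound 2 (1.47 log units; beyond the scatter) and a 20-fold lower number from compound 2 to compound 3 (1.31 log units; beyond the scatter) each involve an oxygen entering or leaving the group and do not speak to ethyl in place of cyclopentyl. For the measured compounds named here, no measured compound carries a group as small as ethyl at this place, so the data allow only a loose expectation. A modest rise in the number is expected for compound 4, a 2.1-fold higher number from compound 3 to compound 4 (0.32 log units; beyond the scatter). Compound 4 is estimated at 110 nM, in the range 30 nM to 400 nM.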

Compound 4, half-maximal inhibitory concentration: 1100 nM
For compound 4 the middle estimate is 10-fold (1.00 log units) below the measured one; measured number outside the range, above it.
By their numbers in this assay, from the lowest: compounds 1 and 3 (each within the scatter of the next); then compounds 2 and 4 (each within the scatter of the next).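

Cutting cyclopentylmethyl back to propyl is not a neutral exchange among groups without oxygen: a 21-fold higher number from compound 3 to compound 4 (1.32 log units; beyond the scatter), and a 31-fold higher number from compound 1 to compound 4 (1.49 log units; beyond the scatter), with hydrogen in place of ethyl on a saturated chain carbon bound to two saturated chain carbons. Oxygen in the group is therefore not needed for a high number, since a 1.0-fold higher number from compound 2 to compound 4 (0.01 log units; within the scatter), and the propyl group of compound 4 stands level with the oxygen-bearing group of compound 2. No evidence is available on what lies behind these steps.

On these data alone, whether a straight butyl or pentyl chain at this place would bring the number back to the level of compound 1 and compound 3 remains open. Also open, as far as these compounds go, is how a cyclobutyl or phenyl group on this saturated chain carbon would read.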